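The source may report more compounds than this note shows. Statements on the series, on what has been measured and on what is new or still open speak of the compounds shown alone.

Measured so far in a physicochemical assay for solubility, read by HPLC, in phosphate buffer, at pH 6.5; on this read-out higher numbers stand for higher solubility and lower numbers for lower solubility:
compound 1 `COC(=O)C1=C(C)NC(c2nccs2)=NC1(C)c1ccc(F)cc1`: 22 ug/mL
compound 2 `COC(=O)C1=C(C)NC(c2nccs2)=NC1(C)c1ccc(F)c(F)c1`: 50 ug/mL

Going by the values given here, compound 1 stands lowest of the two numbers; its nearest neighbour is compound 2, and the only measured step is a 2.3-fold higher number from compound 1 to compound 2 (0.36 log units; beyond the scatter). Compound 3 `COC(=O)C1=C(CN2CCCS2(=O)=O)NC(c2nccs2)=NC1(C)c1ccc(F)cc1` differs from compound 1 by a group of 7 heavy atoms (3 carbon, 1 nitrogen, 2 oxygen, 1 sulfur; one five-membered non-aromatic ring with 2 hetero atoms) in place of a hydrogen atom, on a saturated chain carbon bound to a double-bonded ring carbon. Among the compounds with values here, no measured step touches this kind of change; the fluoro step concerns a different place and group, so it gives no direct guide. The expectation for compound 3 is therefore a modest rise at most, a 1.6-fold higher number from compound 1 to compound 3 (0.20 log units; within the scatter), with a wide range. Compound 3 is estimated at 35 ug/mL, between 10 ug/mL and 120 ug/mL.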

Compound 3, solubility: 125 ug/mL
The estimate for compound 3 lay 3.6-fold (0.55 log units) below the measured number; measured number outside the range, above it.
By their numbers in this assay, from the lowest: compound 1; then compound 2; then compound 3.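

At the saturated chain carbon bound to a double-bonded ring carbon, a place the fluoro step does not touch, a group of 7 heavy atoms in place of a hydrogen atom gives a 5.7-fold higher number from compound 1 to compound 3 (0.75 log units; beyond the scatter) in this assay. This step is larger than the fluoro step, a 2.3-fold higher number from compound 1 to compound 2 (0.36 log units; beyond the scatter), though the two changes sit in different places. No measurement here bears on the origin of the rise.

As far as these compounds go, whether an amine or a carboxylic acid on the same carbon would move the number similarly remains open. So does whether the rise depends on the five-membered non-aromatic ring or would persist with a longer open chain.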